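Methyl in place of methylamino on a carbonyl carbon

This account rests on a few compounds, and the source may have more. Where it says the series, first, only, none or still open, it means among the compounds named here.

Compound 1 `COc1ccc2c(c1)OC(c1cc(OC)c(OC)c(OC)c1)C(C(=O)NC(C)C)=C2` gives > 50000 nM in a functional assay for inhibition of nuclear factor NF-kappa-B complex (Homo sapiens) (on this read-out lower numbers stand for stronger inhibition and higher numbers for weaker inhibition), a limit.
Compound 2 `CNC(=O)C1=Cc2ccc(OC)cc2OC1c1cc(OC)c(OC)c(OC)c1` gives > 50000 nM in this assay, a limit.

Compound 2 therefore stands only at a limit of this assay, not at a number. Compound 3 `COc1ccc2c(c1)OC(c1cc(OC)c(OC)c(OC)c1)C(C(C)=O)=C2` differs from it by methyl in place of methylamino on a carbonyl carbon. For the measured compounds named here, the one measured step, a step that the two limits leave unreadable from compound 1 to compound 2, bears on this: it changed the amide substituent, yet its size is unreadable because of the limit of > 50000 nM in this assay, at which 2 of the 2 values shown sit. Going by the values given here, no size of step can therefore be read for the change to compound 3, and the expectation is that compound 3 remains at the limit too. The expected step that the limit leaves unreadable from compound 2 to compound 3 is estimated as none beyond the scatter. Compound 3 is estimated at 70000 nM, ranging from 20000 nM to 250000 nM.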

Compound 3, half-maximal inhibitory concentration: 14100 nM
For compound 3 the middle estimate is 5.0-fold (0.70 log units) above the measured one, and the stated range ends above it.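

In this assay, compound 3 is the only one shown that gives a number rather than a limit. Acetyl in place of methylcarbamoyl gives an at least 3.5-fold lower number from compound 2 to compound 3 (0.54 log units; beyond the scatter), and acetyl in place of the isopropyl amide gives an at least 3.5-fold lower number from compound 1 to compound 3 (0.54 log units; beyond the scatter), so the read-out does respond to the group on this carbonyl carbon, while the step between the two amides cannot be read: the limit of > 50000 nM in this assay, at which 2 of the 3 values shown sit.

Still open, going by these compounds, is whether the lower number goes with losing the amide hydrogen or with the exchange of groups as a whole. Also open, on these data alone, is how a carboxylic acid or a longer chain in this place would read.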